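Cytotoxicity notes: ester chain length in a quinazoline series

The compounds below may be only part of what the source reports. "The series", "measured", "known", "first", "only" and "open" are said of these compounds alone.

Measured so far:
compound 1 `CCCCCCCCOC(=O)CCC(=O)N1CCN(CCCOc2cc3c(Nc4ccc(F)c(Cl)c4)ncnc3cc2OC)CC1` — 87.3%
compound 2 `CCCCCCCCCCCCCOC(=O)CCC(=O)N1CCN(CCCOc2cc3c(Nc4ccc(F)c(Cl)c4)ncnc3cc2OC)CC1` — 93.7%

In a functional assay on A549 cells (Homo sapiens) for cytotoxicity, read by MTT assay, with a stated time of 24 h, tested at 10 uM (a higher number here means a weaker effect of the compound at the concentration tested, a lower number a stronger effect), compound 2 gives 93.7%, the higher of the two numbers recorded; compound 1 gives 87.3% and stands nearest, separated only by a number 6.4 percentage points higher from compound 1 to compound 2 (within the scatter), so the two cannot be told apart.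

Compound 3 `CCCCCCCCCCCCCCCCOC(=O)CCC(=O)N1CCN(CCCOc2cc3c(Nc4ccc(F)c(Cl)c4)ncnc3cc2OC)CC1` continues the same direction of change: propyl in place of hydrogen on a saturated chain carbon, ten or more bonds along the chain from an oxygen next to a carbonyl group. Among the measured compounds shown here, the one step that bears on it is the earlier chain extension, a number 6.4 percentage points higher from compound 1 to compound 2 (within the scatter), which lay within the scatter. Nothing in the series suggests that a further extension of the ester chain should move this assay beyond the scatter, so a step of no more than the scatter, in either direction, is expected from compound 2 to compound 3.

For compound 3 the expected value is 94%, with a range of 85% to 100%, meaning an expected step of a number 0.3 percentage points higher from compound 2 to compound 3 (within the scatter).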

Compound 3, a percentage reported as activity, at one concentration (the size of the read-out at that concentration, not a potency): 97.7%
Beside the measured number, compound 3's estimate is 3.7 percentage points below it, and the stated range covers the measured number.
By their numbers in this assay, from the lowest: compounds 1, 2 and 3 (each within the scatter of the next, the first and the last beyond it).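

In this assay, adding propyl on a saturated chain carbon gives a number 4 percentage points higher from compound 2 to compound 3 (within the scatter) and so leaves compound 2 and compound 3 indistinguishable. Among the compounds shown here, the full octyl difference gives a number 10.4 percentage points higher from compound 1 to compound 3 (beyond the scatter) and is the first step to clear the scatter, though only modestly, so the two shorter steps separate no neighbours while the ends of the set do stand apart, with compound 3 having the weaker effect at the tested concentration. No supporting measurement is available to account for this result.

Open, on these data alone, is how a methyl or ethyl ester would compare with these long-chain esters in this assay. Also open, as far as these compounds go, is whether a free carboxylic acid at the end of the same linker would give a stronger effect than compound 1.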